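A second methyl on the phenyl ring of compound 2

The compounds below may be only part of what the source reports. "The series", "measured", "known", "first", "only" and "open" are said of these compounds alone.

Compound 1 (`Cc1ccc(N2CCN(C(=S)SCc3ccc4nc(N)nc(N)c4c3)CC2)cc1`) gives 2190 nM
Compound 2 (`Cc1ccccc1N1CCN(C(=S)SCc2ccc3nc(N)nc(N)c3c2)CC1`) gives 3920 nM

In a functional assay on A549 cells (Homo sapiens) for antiproliferative activity, read by MTT assay, with a stated time of 72 h (a lower number here means a stronger inhibitor, a higher number a weaker inhibitor), here, compound 2 gives 3920 nM and sits within the scatter of compound 1 at 2190 nM here, so the two numbers cannot be ranked. Compound 3 (`Cc1ccc(N2CCN(C(=S)SCc3ccc4nc(N)nc(N)c4c3)CC2)c(C)c1`) differs from compound 2 by one change (methyl in place of hydrogen on an aromatic carbon), methyl in place of hydrogen on an aromatic carbon, which turns 2-methylphenyl into 2,4-dimethylphenyl. The new methyl stands meta to a methyl group and para to a large group. Among the compounds with values here, one measured step bears on this, where 2-methylphenyl replaces 4-methylphenyl. Within the data shown here, compound 3 carries both of those methyl groups, yet that step moves a methyl and adds none, so no measured step shows a second methyl being added. Among the measured compounds shown here, with a 1.8-fold higher number from compound 1 to compound 2 (0.25 log units; within the scatter) as the only guide, no step beyond the scatter is expected in this assay here, and no direction is clear. The expected step (a 1.3-fold lower number from compound 2 to compound 3 (0.12 log units; within the scatter)) is estimated to stay small. For compound 3 the estimate is 3000 nM with 1300 nM to 6500 nM as the expected range.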

Compound 3, half-maximal inhibitory concentration: 3000 nM
The estimate for compound 3 equals the measured number at the digits printed; the range from low to high includes it.
By their numbers in this assay, from the lowest: compounds 1, 3 and 2 (each within the scatter of the next).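

Read from either side, 2,4-dimethylphenyl stays within the scatter in this assay: the step is a 1.3-fold lower number from compound 2 to compound 3 (0.12 log units; within the scatter) when the methyl is added to 2-methylphenyl, and a 1.4-fold higher number from compound 1 to compound 3 (0.14 log units; within the scatter) when it is added to 4-methylphenyl. Within the data shown here, earlier, the only step moved a single methyl around the phenyl ring, whereas these two steps are the first to show a second methyl being added, and neither gives a difference that can be read. The three compounds therefore cannot be ranked, and nothing given here offers an explanation for this result.

All three compounds carry only methyl groups on the phenyl ring, so these steps show how far methyl alone is tolerated, not how the ring responds to other kinds of group. As far as these compounds go, it remains open whether a methoxy group, a chlorine atom, an amine or a carboxylic acid in the place of the new methyl, on an aromatic carbon para to the large group, would give a step beyond the scatter.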